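Ethoxy in place of trifluoromethoxy on the shared core

The source may report more compounds than this note shows. Statements on the series, on what has been measured and on what is new or still open speak of the compounds shown alone.

Compound 3 `Cc1cc(C)cc(NC(=O)COc2cc(C)nc3ccc(OC(F)(F)F)cc23)c1` is one of three measured compounds that share a core and differ only in one group on an aromatic carbon. In a toxicity assay on HepG2 cells (Homo sapiens) for inhibition, read by CellTiter-Glo, with a stated time of 48 h (a higher number here means a weaker inhibitor, a lower number a stronger inhibitor), compound 3 gives only a limit, > 100000 nM, and not a number. Compound 2 `Cc1cc(C)cc(NC(=O)COc2cc(C)nc3ccc(Cl)cc23)c1`, which carries a chloro at that carbon, likewise reaches only a limit, > 100000 nM. Compound 1 `COc1ccc2nc(C)cc(OCC(=O)Nc3cc(C)cc(C)c3)c2c1`, with a methoxy there, gives 20000 nM. Two of the three values thus sit at the limit of > 100000 nM in this assay, at which 2 of the 3 values shown sit, so compound 3 sits with compound 2 past the point the assay can resolve, and weaker than compound 1. The step of an at least 5.0-fold higher number from compound 1 to compound 3 (0.69 log units; beyond the scatter) and the step of an at least 5.0-fold higher number from compound 1 to compound 2 (0.69 log units; beyond the scatter) both run toward weaker inhibition, while the step that the two limits leave unreadable from compound 2 to compound 3 cannot be sized.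

The new compound 4 `CCOc1ccc2nc(C)cc(OCC(=O)Nc3cc(C)cc(C)c3)c2c1` is compound 3 with ethyl in place of trifluoromethyl on an oxygen on an aromatic ring. This change undoes part of the move from compound 1 to compound 3: the oxygen stays, and an ethyl replaces the trifluoromethyl. Among the compounds with values here, the only step that bears on it is an at least 5.0-fold higher number from compound 1 to compound 3 (0.69 log units; beyond the scatter), which read backwards points compound 4 toward compound 1. Compound 4 is therefore expected to show the step of an at least 2.8-fold lower number from compound 3 to compound 4 (0.45 log units; beyond the scatter), toward a lower number. The estimate for compound 4 in this assay is 35000 nM, with a range from 12000 nM to 100000 nM.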

Compound 4, half-maximal inhibitory concentration: > 100000 nM
Compound 4: only a limit was reported (the forecaster's own chance of this, stated with the estimate: 35%); middle value at least 2.8-fold (0.45 log units) from the limit.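

Ethoxy does not bring the shared core back toward compound 1, as the trifluoromethoxy comparison had suggested it might. Compound 4 gives only a limit in this assay, > 100000 nM, so adding one methyl to the methoxy of compound 1 already produces an at least 5.0-fold higher number from compound 1 to compound 4 (0.69 log units; beyond the scatter), and this small change on the oxygen moves the result toward weaker inhibition. Among the four compounds, methoxy is now the only group on this aromatic carbon that gives a number, and the steps among compound 2, compound 3 and compound 4 cannot be read because all three stop at the same ceiling: the limit of > 100000 nM in this assay, at which 3 of the 4 values shown sit.

The compounds shown leave open how far past that limit compound 2, compound 3 and compound 4 lie, and so whether chloro, trifluoromethoxy and ethoxy differ from one another at all. They also leave open whether methoxy is alone in giving a readable value here, which a hydroxyl group or an amine on the same aromatic carbon could begin to test.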